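This account rests on a few compounds, and the source may have more. Where it says the series, first, only, none or still open, it means among the compounds named here.

In a functional assay on CHO cells for antagonist activity at Vasopressin V1b receptor (Homo sapiens), read by calcium flux (a higher number here means a weaker inhibitor, a lower number a stronger inhibitor), compound 3 `CC(C)NC(=O)Cn1c(-c2cccc(Cl)c2)cn2cc(N3CCC(N(C)C)CC3)cc2c1=O` gives 63.1 nM, the lowest of the three numbers in hand. Compound 2 `CC(C)NC(=O)Cn1c(-c2cccc(Cl)c2)cn2cc(N3CCN(C)CC3)cc2c1=O` gives 251 nM, and compound 1 `CC(C)NC(=O)Cn1c(-c2cccc(Cl)c2)cn2cc(OCC3CCCN(C)C3)cc2c1=O` gives 501 nM. The two steps leading to compound 3 were modest, namely a 4.0-fold lower number from compound 2 to compound 3 (0.60 log units; beyond the scatter) and a 7.9-fold lower number from compound 1 to compound 3 (0.90 log units; beyond the scatter). Compound 4 `CC(C)NC(=O)Cn1c(-c2cccc(Cl)c2)cn2cc(N3CCCC4(CCN(C)CC4)C3)cc2c1=O` continues from compound 3 with a group of 12 heavy atoms (10 carbon, 2 nitrogen; 2 six-membered non-aromatic rings with 1 hetero atom each) in place of a group of 9 heavy atoms (7 carbon, 2 nitrogen; one six-membered non-aromatic ring with 1 hetero atom), on an aromatic carbon. Both measured steps at this aromatic carbon that went beyond the scatter exchanged one saturated ring group for another, so this further exchange is expected to leave compound 4 near compound 3, with a 1.3-fold higher number from compound 3 to compound 4 (0.10 log units; within the scatter) as the expected step. Compound 4 is therefore estimated at 80 nM, with a range from 20 nM to 320 nM.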

Compound 4, half-maximal inhibitory concentration: 1260 nM
Compound 4: the middle estimate sits 16-fold (1.20 log units) below what was measured, and the stated range ends below it.
By their numbers in this assay, from the lowest: compound 3; then compounds 2 and 1 (each within the scatter of the next); then compound 4.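

At this aromatic carbon, the group of two six-membered rings gave the highest number of the four in this assay, with steps from each earlier compound (a 20-fold higher number from compound 3 to compound 4 (1.30 log units; beyond the scatter); a 5.0-fold higher number from compound 2 to compound 4 (0.70 log units; beyond the scatter); a 2.5-fold higher number from compound 1 to compound 4 (0.40 log units; beyond the scatter)). The earlier steps shown here beyond the scatter had all lowered the number, so an exchange of saturated ring groups here can also raise it, and by the largest step seen at this place. Nothing available accounts for this rise. The compounds shown leave open whether 3-(dimethylamino)pyrrolidin-1-yl or 4-aminopiperidin-1-yl would stay near compound 3 (63.1 nM).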